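Notes on the step from compound 2 to compound 4

This account rests on a few compounds, and the source may have more. Where it says the series, first, only, none or still open, it means among the compounds named here.

Measured compounds:
- compound 1 `Nc1ccn([C@@H]2C=C(F)[C@H](CO)O2)c(=O)n1`: > 100000 nM
- compound 2 `Cc1cn([C@@H]2C=C(F)[C@H](CO)O2)c(=O)nc1O`: > 100000 nM
- compound 3 `Cc1cn([C@H]2C=C(F)[C@H](CO)O2)c(=O)nc1O`: > 100000 nM

All three readings come from a functional assay on Vero cells (Chlorocebus sabaeus) for cytotoxicity (on this read-out lower numbers stand for stronger inhibition and higher numbers for weaker inhibition), and each is a limit, not a number. Compound 2 therefore has only a limit, > 100000 nM, and no position can be ranked within the set: the limit of > 100000 nM in this assay, at which 3 of the 3 values shown sit.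

The change to compound 4 `O=c1nc(O)ccn1[C@@H]1C=C(F)[C@H](CO)O1` is hydrogen in place of methyl on an aromatic carbon.

For the measured compounds named here, the only measured step is a step that the two limits leave unreadable from compound 2 to compound 3. It reflects (the fact that compounds 2 and 3 differ only in the configuration as drawn), so it does not touch the methyl and gives no size or direction for this change. With no readable step to go on, and with the limit of > 100000 nM in this assay, at which 3 of the 3 values shown sit, no step beyond the scatter is expected in this assay. The expected step is a number no higher from compound 2 to compound 4 (the limit leaves the size open), and a reading at the same limit is the likeliest result. For compound 4 the estimated value is 100000 nM, with an expected range of 50000 nM to 200000 nM.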

Compound 4, half-maximal inhibitory concentration: > 100000 nM
Compound 4 ended at the assay's limit; the forecaster's own chance of this, stated with the estimate: 85%; the middle value sits exactly at the limit.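

In this assay, for the compounds shown here, compound 4 gives > 100000 nM, a limit and not a number, so no step to compound 4 from compound 1 or compound 2 can be read. The compounds shown leave open whether either change has any effect on this read-out.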